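The source may hold more compounds than are shown below. What is called first, only, known or untested is meant among the compounds shown, and "the series" means these compounds.

Compound 1 `O=C(C1CC1)N1CCc2nc(C#Cc3ccccc3)sc2C1` gives 290 nM in an assay on HEK293 cells for negative allosteric modulation of metabotropic glutamate receptor 5 (Homo sapiens), read by FLIPR, with a stated time of 1 h; a lower number here means a stronger inhibitor, a higher number a weaker inhibitor. Compound 2 `O=C(C1CC12CCC2)N1CCc2nc(C#Cc3ccccc3)sc2C1` reaches only a limit in this assay, > 10000 nM, which is the limit of > 10000 nM in this assay, at which 1 of the 2 values shown sits. The change an at least 34-fold higher number from compound 1 to compound 2 (1.53 log units; beyond the scatter) is therefore a large loss. Compound 3 `CC1CC(C(=O)N2CCc3nc(C#Cc4ccccc4)sc3C2)C1` differs from compound 2 by a group of 5 heavy atoms (5 carbon; one four-membered non-aromatic ring of carbon only) in place of a group of 6 heavy atoms (6 carbon; one three-membered non-aromatic ring of carbon only, one four-membered non-aromatic ring of carbon only), on a carbonyl carbon. The enlargement on this carbonyl carbon cost heavily from compound 1 to compound 2, so the smaller group of compound 3 is expected to recover part of that loss, giving an estimated at least 8.3-fold lower number from compound 2 to compound 3 (0.92 log units; beyond the scatter). Compound 3 is estimated at 1200 nM, within 250 nM to 6000 nM, though the limit of compound 2 leaves the true size of the step uncertain.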

Compound 3, half-maximal inhibitory concentration: > 10000 nM
Compound 3 was reported as a limit; the forecaster's own chance of this, stated with the estimate: 20%; middle value at least 8.3-fold (0.92 log units) from the limit.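

Compound 3 also stops at a limit in this assay: the limit of > 10000 nM in this assay, at which 2 of the 3 values shown sit. Putting 3-methylcyclobutyl in place of cyclopropyl on this carbonyl carbon gives an at least 34-fold higher number from compound 1 to compound 3 (1.53 log units; beyond the scatter), so the large loss is not confined to the group of compound 2 and appears with a second group that has no three-membered ring. The step between compound 2 and compound 3 cannot be read, as both values are limits. From the compounds shown here alone, whether unsubstituted cyclobutyl or a smaller group such as methyl on this carbonyl carbon would keep the level of compound 1, 290 nM, stays open. So does the effect of an amine on a ring of this size.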